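Chalcone series: trimethoxyphenyl in place of guaiacol at compound 4

A few compounds are considered here, and "the series" means these few. Any claim that something is new, unique, unknown or untested is made for them only; others in the source may bear on it.

Compound 3 `COc1ccc(-c2cn(-c3cccc(C(=O)/C=C/c4ccc(O)c(OC)c4)c3)c(=O)[nH]2)cc1` gives 5840 nM in a functional assay on SNB-19 cells (Homo sapiens) for inhibition (a lower number here means a stronger inhibitor of growth, a higher number a weaker inhibitor of growth), the second highest of the three numbers shown. Compound 2 `COc1cc(/C=C/C(=O)c2cccc(-n3cc(-c4ccccc4)[nH]c3=O)c2)cc(OC)c1OC` gives 2350 nM and compound 1 `COc1cc(/C=C/C(=O)c2cccc(-n3cc(-c4ccc(Cl)cc4)[nH]c3=O)c2)cc(OC)c1OC` gives 16100 nM. For the measured compounds named here, the only measured single-point step is a 6.9-fold lower number from compound 1 to compound 2 (0.84 log units; beyond the scatter), which concerns a different part of the structure and does not bear on the present change. Compound 4 `COc1ccc(-c2cn(-c3cccc(C(=O)/C=C/c4cc(OC)c(OC)c(OC)c4)c3)c(=O)[nH]2)cc1` arises from compound 3 by 3,4,5-trimethoxyphenyl in place of 4-hydroxy-3-methoxyphenyl on a double-bonded chain carbon bound to a double-bonded chain carbon. Going by the values given here, no measured step covers this change directly; compounds 1 and 2 both carry the entering group and their numbers bracket compound 3 on either side. Compound 4 is therefore expected to land within the span already seen, with a 1.2-fold lower number from compound 3 to compound 4 (0.07 log units; within the scatter) as the expected step, giving an estimate of 5000 nM with a range of 1500 nM to 16000 nM.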

Compound 4, concentration for 50% growth inhibition: 4380 nM
Compound 4: the middle estimate sits 1.1-fold (0.06 log units) above what was measured; the measured number falls inside the stated range.
By their numbers in this assay, from the lowest: compounds 2, 4 and 3 (each within the scatter of the next, the first and the last beyond it); then compound 1.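

With 3,4,5-trimethoxyphenyl in place of 4-hydroxy-3-methoxyphenyl, this assay gives a 1.3-fold lower number from compound 3 to compound 4 (0.12 log units; within the scatter), so this exchange on the double-bonded chain carbon leaves the number within the scatter despite the loss of the hydrogen-bond donor. With the trimethoxyphenyl group held, methoxy in place of hydrogen on an aromatic carbon gives a 1.9-fold higher number from compound 2 to compound 4 (0.27 log units; within the scatter), whereas methoxy in place of chloro gives a 3.7-fold lower number from compound 1 to compound 4 (0.57 log units; beyond the scatter), leaving compound 1 apart from the other three. No available evidence accounts for these steps. Still open, as far as these compounds go, is how an amine or a carboxylic acid on this phenyl ring would read. Also open, from the compounds shown here alone, is whether the same exchange gives a similar step when chloro replaces methoxy on the aromatic carbon.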